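A few compounds are considered here, and "the series" means these few. Any claim that something is new, unique, unknown or untested is made for them only; others in the source may bear on it.

Of the compounds shown here, three have been tested in a functional assay on the whole organism (strain Wistar) for inhibition, with Rattus norvegicus as the target, with stated times of 30 min and 2 h, at a dose of 20 mg/kg by the oral route; on this read-out higher numbers stand for more inhibition at the one dose given (going by the name of the read-out) and lower numbers for less inhibition. Compound 1 `O=C(CCc1nnc(-c2ccccc2Cl)o1)c1ccccc1` gives 26.9%, compound 2 `Cc1ccc(C(=O)CCc2nnc(-c3ccccc3Cl)o2)cc1` gives 36.2%, and compound 3 `Cc1ccc(C(=O)CCc2nnc(-c3ccccc3Cl)o2)c(C)c1` gives 33.5%. Compound 3 stands second highest of the three numbers, with a number 2.7 percentage points lower from compound 2 to compound 3 (within the scatter) and a number 6.6 percentage points higher from compound 1 to compound 3 (within the scatter), both within the scatter, as is a number 9.3 percentage points higher from compound 1 to compound 2 (within the scatter). Compound 4 `COc1ccc(-c2nnc(CCC(=O)c3ccc(C)cc3C)o2)cc1` differs from compound 3 by 4-methoxyphenyl in place of 2-chlorophenyl on an aromatic carbon. Going by the values given here, none of the measured steps touches this ring; all three alter the phenyl on the carbonyl carbon, and all three stayed within the scatter. So no measured step bears on this change, and no step beyond the scatter is expected in this assay. Compound 4 is estimated at 30%, within 15% to 45%, meaning an expected step of a number 3.5 percentage points lower from compound 3 to compound 4 (within the scatter).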

Compound 4, a percentage reported as inhibition, in the whole organism at one dose (the size of the read-out at that dose, not a potency): 62.7%
For compound 4 the middle estimate is 32.7 percentage points below the measured one; measured number outside the range, above it.
By their numbers in this assay, from the lowest: compounds 1, 3 and 2 (each within the scatter of the next); then compound 4.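

In this assay, putting 4-methoxyphenyl in place of 2-chlorophenyl on the five-membered aromatic ring gives a number 29.2 percentage points higher from compound 3 to compound 4 (beyond the scatter). This position can therefore move the read-out well beyond the scatter, unlike the changes to the phenyl on the carbonyl carbon, which all stayed within it. Nothing available explains the size of this step.

On these data alone, the step removes the chlorine and adds the methoxy at once, so the share of each remains open. A plain phenyl or a 4-aminophenyl at this position could begin to separate them.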